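The compounds below may be only part of what the source reports. "The series", "measured", "known", "first", "only" and "open" are said of these compounds alone.

Compound 1, `COc1cc2cc(C#N)ccc2c(OC)c1Oc1cc(NCC(C)(C)C)nc(Nc2ccc(C#N)cc2)n1`, in an ADME assay on MT4 cells (Homo sapiens) for cytotoxicity, read by MTT assay, with a stated time of 5 days (a lower number here means that less compound is tolerated, a higher number that more compound is tolerated), gives > 125000 nM, which is a limit of the assay rather than a number.
Compound 2, `COc1cc2cc(C#N)ccc2c(OC)c1Oc1cc(NCCCOC(C)C)nc(Nc2ccc(C#N)cc2)n1`, in this assay gives > 125000 nM, again a limit.
Compound 3, `COc1cc2cc(C#N)ccc2c(OC)c1Oc1cc(NCC2CC2)nc(Nc2ccc(C#N)cc2)n1`, in this assay gives > 125000 nM, also a limit.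

All three values sit at the limit of > 125000 nM in this assay, at which 3 of the 3 values shown sit, so compound 3 stands level with its two companions only in the sense that none of the three is resolved beyond the limit. The steps a step that the two limits leave unreadable from compound 1 to compound 2, a step that the two limits leave unreadable from compound 1 to compound 3 and a step that the two limits leave unreadable from compound 2 to compound 3 all bear on the change considered here, since each alters the group on a saturated chain carbon bound to a nitrogen on an aromatic ring, yet every one of them is left unreadable by the limits and yields no size. The unmeasured compound 4, `COc1cc2cc(C#N)ccc2c(OC)c1Oc1cc(NCCCCO)nc(Nc2ccc(C#N)cc2)n1`, differs from compound 3 by 3-hydroxypropyl in place of cyclopropyl on a saturated chain carbon bound to a nitrogen on an aromatic ring. As no earlier change at this position moved a value off the limit, the expected step in this assay is none beyond the scatter, and the estimated step is a number no higher from compound 3 to compound 4 (the limit leaves the size open). Compound 4 is therefore expected to give 125000 nM in this assay, within 60000 nM to 250000 nM, most likely again reported only as a limit.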

Compound 4, half-maximal cytotoxic concentration: 39100 nM
The estimate for compound 4 lay 3.2-fold (0.50 log units) above the measured number, and the stated range ends above it.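

Among the compounds shown here, the position is not indifferent in this assay: 3-hydroxypropyl in place of cyclopropyl gives an at least 3.1-fold lower number from compound 3 to compound 4 (0.50 log units; beyond the scatter), the first readable change here. The same holds against the other two side chains, with an at least 3.1-fold lower number from compound 1 to compound 4 (0.50 log units; beyond the scatter) for the swap from tert-butyl and an at least 3.1-fold lower number from compound 2 to compound 4 (0.50 log units; beyond the scatter) for hydroxymethyl in place of isopropoxy, so the chain of compound 2, which also carries an oxygen, does not show this drop. Each of these sizes is only a minimum, and compound 4 alone stands off the limit: the limit of > 125000 nM in this assay, at which 3 of the 4 values shown sit.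

The compounds shown do not separate the hydroxyl from the open chain, and a plain butyl chain, a 4-aminobutyl group or a carboxylic acid would bear on that. The steps among compound 1, compound 2 and compound 3 still cannot be read.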